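Azido-hydroxypropyl in place of nitrobenzyl on the shared core

The source may hold more compounds than are shown below. What is called first, only, known or untested is meant among the compounds shown, and "the series" means these compounds.

Measured compounds:
compound 1 `C=CCn1c(=O)n(CCCCO)c2nc(N)nc(O)c21` — 12%
compound 2 `Nc1nc(O)c2c(n1)n(C1OC(CO)[C@@H](O)[C@H]1O)c(=O)n2Cc1ccc([N+](=O)[O-])cc1` — 147%

In a functional assay on the whole organism (B cells) with Mus musculus as the target (a higher number here means a larger maximal response, a lower number a smaller maximal response), compound 2 gives 147%, the highest of the two numbers; compound 1 gives 12%, a gap beyond the scatter. Compound 3 `[N-]=[N+]=NCC(O)Cn1c(=O)n(C2OC(CO)[C@@H](O)[C@H]2O)c2nc(N)nc(O)c21` is not yet measured. It differs from compound 2 by 2-azido-1-hydroxyethyl in place of 4-nitrophenyl on a saturated chain carbon bound to an aromatic nitrogen. Among the compounds with values here, no step between measured compounds covers this change. Since compound 1, which carries only short chains on the core, gives 12%, a loss of maximal response is expected, moderate to large: a number 87 percentage points lower from compound 2 to compound 3 (beyond the scatter) is the estimated step. For compound 3 the expected value is 60%, within 15% to 130%.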

Compound 3, largest response reached (reported as maximal response), in percent of the reference or control that the assay uses: 91%
Beside the measured number, compound 3's estimate is 31 percentage points below it, within the range that was stated.
By their numbers in this assay, from the lowest: compound 1; then compound 3; then compound 2.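

In this assay, 2-azido-1-hydroxyethyl in place of 4-nitrophenyl on a saturated chain carbon bound to an aromatic nitrogen gives a number 56 percentage points lower from compound 2 to compound 3 (beyond the scatter), so the maximal response depends on the group at this position. The entering group has no ring, yet compound 3 gives 91%, so a six-membered aromatic ring of carbon only is not needed at this position for a response of that size. Nothing available explains the step.

Going by these compounds, it remains open whether the azide or the hydroxyl of the entering group accounts for the difference from compound 2. On these data alone, how an unsubstituted benzyl or a 3-aminopropyl group would read at this position also remains open.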